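The source may hold more compounds than are shown below. What is called first, only, known or untested is meant among the compounds shown, and "the series" means these compounds.

In a functional assay on CHO cells for positive allosteric modulation of metabotropic glutamate receptor 2 (Homo sapiens), read by scintillation counting and GTPgammaS binding, with a stated time of 30 min (a higher number here means that more compound is needed for the effect, a lower number that less compound is needed), compound 1 `CC(C)CCn1ccc(-c2ccccc2)c(C#N)c1=O` gives 8510 nM, compound 2 `COc1ccc(-c2ccn(CCC(C)C)c(=O)c2C#N)cc1` gives 1150 nM, and compound 3 `COc1ccc(-c2ccn(CCC(C)C)c(=O)c2C#N)cc1Cl` gives 363 nM. Compound 2 stands second highest of the three numbers, with compound 3 nearest at a lower number and compound 1 furthest at a higher one. The two steps that join them are a 7.4-fold lower number from compound 1 to compound 2 (0.87 log units; beyond the scatter) and a 3.2-fold lower number from compound 2 to compound 3 (0.50 log units; beyond the scatter). Compound 4 `CC(C)CCn1ccc(-c2ccc(OCC3CC3)cc2)c(C#N)c1=O` differs from compound 2 by cyclopropyl in place of hydrogen on a saturated chain carbon bound to an oxygen on an aromatic ring. Neither measured step touches that chain carbon: both replace a hydrogen on an aromatic carbon, and both lowered the number in this assay by a modest amount. The change to compound 4 thus has no direct precedent among these compounds, and the only guide is that the additions seen in compound 2 and compound 3 moved the number down. Compound 4 is therefore expected to give a number in this assay around 600 nM, within a range from 150 nM to 2500 nM. That expectation amounts to an estimated step of a 1.9-fold lower number from compound 2 to compound 4 (0.28 log units; within the scatter).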

Compound 4, half-maximal effective concentration: 290 nM
Compound 4: the middle estimate sits 2.1-fold (0.32 log units) above what was measured, within the range that was stated.
By their numbers in this assay, from the lowest: compounds 4 and 3 (each within the scatter of the next); then compound 2; then compound 1.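

Both earlier steps replaced a hydrogen on an aromatic carbon, whereas this change acts on the saturated chain carbon bound to the oxygen, turning methoxy into cyclopropylmethoxy. In this assay that carbon accepts the cyclopropyl group and the number still falls, with a 4.0-fold lower number from compound 2 to compound 4 (0.60 log units; beyond the scatter). Taken as one change, cyclopropylmethoxy in place of hydrogen on an aromatic carbon gives a 29-fold lower number from compound 1 to compound 4 (1.47 log units; beyond the scatter), the only large step among these compounds. Nothing available explains why the number falls with this change.

From the compounds shown here alone, it remains open whether the three-membered ring itself matters, or whether an open chain such as propoxy or butoxy would serve equally well. Also open, going by these compounds, is how an amine or a carboxylic acid on that chain would behave, and whether chloro on the aromatic ring would add to the effect of cyclopropylmethoxy.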